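Removing the ester from compound 3: what to expect

A few compounds are considered here, and "the series" means these few. Any claim that something is new, unique, unknown or untested is made for them only; others in the source may bear on it.

Three compounds share one core and differ only in the group on a saturated ring carbon. Compound 1 `O=C(OC1CCC(CN2CCN(c3cc(=O)c4cc(C(F)(F)F)cc([N+](=O)[O-])c4s3)CC2)CC1)C1CCCCC1` carries a cyclohexylcarbonyl ester; compound 2 `O=c1cc(N2CCN(CC3CCC(O)CC3)CC2)sc2c([N+](=O)[O-])cc(C(F)(F)F)cc12` carries a free hydroxyl; compound 3 `Cc1ccc(C(=O)OC2CCC(CN3CCN(c4cc(=O)c5cc(C(F)(F)F)cc([N+](=O)[O-])c5s4)CC3)CC2)cc1` carries a (4-methylphenyl)carbonyl ester. In an ADME assay on cells (Hepatocyte, Homo sapiens) for metabolic stability, with a stated time of 30 min (on this read-out lower numbers stand for a less stable compound and higher numbers for a more stable compound), compound 1 gives 2.8%, compound 2 gives 72.7%, and compound 3 gives 9.7%. Compound 3 thus stands second highest of the three, close to compound 1 and far below compound 2.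

Compound 4 `O=c1cc(N2CCN(CC3CCCCC3)CC2)sc2c([N+](=O)[O-])cc(C(F)(F)F)cc12` is compound 3 with the ester taken away entirely: hydrogen in place of ((4-methylphenyl)carbonyl)oxy on a saturated ring carbon. Going by the values given here, two measured steps bear on this change. The step of a number 69.9 percentage points higher from compound 1 to compound 2 (beyond the scatter) shows that losing an ester in favour of a hydroxyl raised the number greatly, and the step of a number 63 percentage points lower from compound 2 to compound 3 (beyond the scatter) shows the reverse change lowered it by a similar amount. Among the compounds with values here, no measured pair tells how a hydroxyl compares with a bare hydrogen, so some uncertainty remains. A large upward step is therefore expected, a number 50.3 percentage points higher from compound 3 to compound 4 (beyond the scatter). Compound 4 is estimated to give 60% in this assay, with a likely range from 35% to 85%.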

Compound 4, percent of the compound remaining: 82.4%
Compound 4: middle estimate off by 22.4 percentage points, on the low side; low and high end bracket the measured number.
By their numbers in this assay, from the lowest: compounds 1 and 3 (each within the scatter of the next); then compounds 2 and 4 (each within the scatter of the next).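

Taking the whole ester off and leaving only hydrogen on the saturated ring carbon gives, in this assay, a number 72.7 percentage points higher from compound 3 to compound 4 (beyond the scatter) and, for the other ester, a number 79.6 percentage points higher from compound 1 to compound 4 (beyond the scatter) at the same position. The new comparison is between the hydroxyl and bare hydrogen: a number 9.7 percentage points higher from compound 2 to compound 4 (within the scatter) on this read-out, so the two cannot be told apart. A high number therefore does not require the hydroxyl here; among these four compounds, the two esters give low numbers and the two compounds without an ester give high numbers.

The compounds shown leave open how an amine or a carboxylic acid on this carbon would compare, and whether a simple methyl ether would stay with compound 2 and compound 4 or fall towards the esters. No measurement given here explains the gap between the esters and the other two compounds.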